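A few compounds are considered here, and "the series" means these few. Any claim that something is new, unique, unknown or untested is made for them only; others in the source may bear on it.

In a functional assay on MCF7 cells (Homo sapiens) for cytotoxicity, read by MTT assay, with a stated time of 72 h (on this read-out higher numbers stand for weaker inhibition and lower numbers for stronger inhibition), the measured compounds stand as follows: compound 1 `Cc1ccc(-n2nc(C(=O)Nc3ccc(Oc4ncnc5ccsc45)c(F)c3)c(C)cc2=O)cc1` gives 7250 nM; compound 2 `Cc1cc(=O)n(-c2ccc(F)cc2)nc1C(=O)Nc1ccc(Oc2ncnc3ccsc23)c(F)c1` gives 740 nM. Compound 3 `Cc1ccc(-n2nc(C(=O)Nc3ccc(Oc4ncnc5sccc45)cc3)c(C)cc2=O)cc1` gives only a limit, > 40000 nM.

Compound 1 and compound 2 differ by fluoro in place of methyl on an aromatic carbon, and that change brought a 9.8-fold lower number from compound 1 to compound 2 (0.99 log units; beyond the scatter). Compound 3 carries a different core from compound 1; the difference between the two cores is not broken down here. The unmeasured compound 4 `Cc1cc(=O)n(-c2ccc(F)cc2)nc1C(=O)Nc1ccc(Oc2ncnc3sccc23)cc1` differs from compound 3 by fluoro in place of methyl on an aromatic carbon, the same change as between compound 1 and compound 2. A step of an at least 2.6-fold lower number from compound 3 to compound 4 (0.42 log units; beyond the scatter) is expected, resting on a 9.8-fold lower number from compound 1 to compound 2 (0.99 log units; beyond the scatter). Yet compound 3 sits at the limit of > 40000 nM in this assay, at which 1 of the 3 values shown sits, so the starting point is not a number, and compound 4 may likewise give only a limit. Compound 4 is therefore expected near 15000 nM, roughly between 3000 nM and 60000 nM.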

Compound 4, half-maximal inhibitory concentration: 21000 nM
Compound 4: middle estimate off by 1.4-fold (0.15 log units), on the low side; the measured number falls inside the stated range.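

Carried to the core of compound 3, the change from 4-methylphenyl to 4-fluorophenyl gave, in this assay, an at least 1.9-fold lower number from compound 3 to compound 4 (0.27 log units; that floor lies within the scatter). Compound 3 gives > 40000 nM, which is a limit of the assay and not a number, so this shows a change that did not reverse on the second core, but not a step of known size. Whether the change carries over at the same size remains unsettled: the same change on two cores in this assay, a 9.8-fold lower number (0.99 log units; beyond the scatter) from compound 1 to compound 2 and an at least 1.9-fold lower number (0.27 log units; that floor lies within the scatter) from compound 3 to compound 4; the limit leaves it open whether they differ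

The compounds shown leave open how a chloro group, a methoxy group or an amine would read on that same aromatic carbon. They also leave open what size the step would take on a third core.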